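The source may hold more compounds than are shown below. What is called first, only, known or untested is meant among the compounds shown, and "the series" means these compounds.

Of the compounds shown here, two have been measured so far, compound 1 `CC(C)c1ccc(NCC(=O)N[C@H]2CCOC2=O)cc1` and compound 2 `O=C(CNc1cccc(Cl)c1)N[C@H]1CCOC1=O`, which share one core and differ only in the group on the aromatic ring. In a functional assay on MCF7 cells (Homo sapiens) for antiproliferative activity, read by MTT assay, with a stated time of 72 h (a higher number here means a weaker inhibitor, a lower number a stronger inhibitor), compound 1 gives only a limit, > 64000 nM, and not a number. In this assay compound 2 likewise gives only a limit, > 64000 nM. Within the data shown here, compound 2 therefore cannot be placed on a scale of numbers: both values sit at the same limit, as the limit of > 64000 nM in this assay, at which 2 of the 2 values shown sit, shows, and no step between the two measured compounds can be sized. Compound 3 `O=C(CNc1ccccc1)N[C@H]1CCOC1=O` differs from compound 2 by hydrogen in place of chloro on an aromatic carbon. Nothing measured here points to a change in either direction from compound 2 to compound 3 that would reach beyond the scatter, since both known values are limits. The estimate is that compound 3 also ends at a limit, with an expected value of 100000 nM in a range of 30000 nM to 400000 nM, the expected step being a step that the limit leaves unreadable from compound 2 to compound 3.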

Compound 3, half-maximal inhibitory concentration: > 64000 nM
Compound 3: a limit, no number; the forecaster's own chance of this, stated with the estimate: 85%; the middle value lies beyond the limit too.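

In this assay compound 3 also gives only a limit, so no step from it to compound 1 or compound 2 can be read: the limit of > 64000 nM in this assay, at which 3 of the 3 values shown sit.

The compounds shown leave open how hydrogen, chloro and isopropyl on the aromatic carbon compare in this assay.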